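Furan-2-yl in Place of Phenyl: An Expected Step

This account rests on a few compounds, and the source may have more. Where it says the series, first, only, none or still open, it means among the compounds named here.

Three compounds were measured in an assay on cells for displacement of a labelled ligand from adenosine receptor A1 (Homo sapiens), with a stated time of 60 min, tested at 1 uM; on this read-out higher numbers stand for more inhibition at the one concentration tested (going by the name of the read-out) and lower numbers for less inhibition. Compound 1 `CCOC(=O)C1=C(C)N/C(=N\C#N)NC1c1ccco1` gives 27% in this assay. Compound 2 `CCOC(=O)C1=C(C)N/C(=N\C#N)NC1c1ccccc1` gives 18%, and compound 3 `CC1=C(C(=O)OC(C)C)C(c2ccccc2)N/C(=N/C#N)N1` gives 20%. All three numbers lie within the scatter of one another, so none of them is set apart from the others.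

Two single changes connect the measured compounds. Between compound 2 and compound 1 the change is furan-2-yl in place of phenyl on a saturated ring carbon, and the step is a number 9 percentage points higher from compound 2 to compound 1 (within the scatter). Between compound 2 and compound 3 the change is methyl in place of hydrogen on a saturated chain carbon bound to an oxygen next to a carbonyl group and a saturated chain carbon, with the step of a number 2 percentage points higher from compound 2 to compound 3 (within the scatter); this is also how the core of compound 3 differs from the core of compound 2.

Compound 4 `CC1=C(C(=O)OC(C)C)C(c2ccco2)N/C(=N/C#N)N1` has not been measured. It differs from compound 3 by furan-2-yl in place of phenyl on a saturated ring carbon. This is the same kind of change as the one from compound 2 to compound 1, and it occurs twice among these compounds, but the surroundings differ: in compound 4 the saturated ring carbon is next to the ring atom that bears an isopropoxycarbonyl group, whereas in compound 1 it is next to the ring atom that bears an ethoxycarbonyl group.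

The expectation rests on a single earlier occurrence, because that occurrence gave a number 9 percentage points higher from compound 2 to compound 1 (within the scatter), a step that itself lies within the scatter. For compound 4 the expected step is a number 7 percentage points higher from compound 3 to compound 4 (within the scatter). Compound 4 is therefore estimated at 27% in this assay. Compound 4 is expected to fall between 12% and 42%.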

Compound 4, a percentage reported as inhibition, at one concentration (the size of the read-out at that concentration, not a potency): 21%
Beside the measured number, compound 4's estimate is 6 percentage points above it; the range from low to high includes it.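

In this assay furan-2-yl in place of phenyl on a saturated ring carbon now gives a number 1 percentage points higher from compound 3 to compound 4 (within the scatter) on the core of compound 3, and beside its earlier occurrence the change does not differ between the two cores: the same change on two cores in this assay, a number 9 percentage points higher (within the scatter) from compound 2 to compound 1 and a number 1 percentage points higher (within the scatter) from compound 3 to compound 4, 8 percentage points apart, within the scatter of two such steps. The other change, methyl in place of hydrogen on a saturated chain carbon bound to an oxygen next to a carbonyl group and a saturated chain carbon, can now also be read on the furan-2-yl compounds as a number 6 percentage points lower from compound 1 to compound 4 (within the scatter) and likewise does not differ between the two cores: the same change on two cores in this assay, a number 2 percentage points higher (within the scatter) from compound 2 to compound 3 and a number 6 percentage points lower (within the scatter) from compound 1 to compound 4, 8 percentage points apart, within the scatter of two such steps. This shows that, across these four compounds, neither change gave a step on one core that differed from its step on the other, but it does not show that either change has a real effect of its own, as every step lies within the scatter and each change has only two occurrences.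

The compounds shown leave open whether a different group on the saturated ring carbon, such as cyclohexyl or a thiophene ring, would give a number set apart from these four. They also leave open what a longer chain on the ester, or a carboxylic acid in its place, would do in this assay.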